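This account rests on a few compounds, and the source may have more. Where it says the series, first, only, none or still open, it means among the compounds named here.

Measured so far:
compound 1 `CCc1nc(N)nc(N)c1-c1ccc(NCc2ccc(S(C)(=O)=O)cc2)cc1` — 7.4 nM
compound 2 `CCc1nc(N)nc(N)c1-c1ccc(NCc2ccc([N+](=O)[O-])cc2)cc1` — 11 nM

In an in vitro assay on CHOK cells for displacement of a labelled ligand from growth hormone secretagogue receptor type 1 (Homo sapiens) (a lower number here means a stronger inhibitor, a higher number a weaker inhibitor), compound 1 gives 7.4 nM and compound 2 gives 11 nM. Compound 2 holds the highest of the two numbers, but its nearest neighbour is compound 1 and the step of a 1.5-fold higher number from compound 1 to compound 2 (0.17 log units; within the scatter) lies within the scatter, so the two cannot be ordered.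

Compound 3 `CCc1nc(N)nc(N)c1-c1ccc(NCc2ccc(C(C)=O)cc2)cc1` is not yet measured. It differs from compound 2 by acetyl in place of nitro on an aromatic carbon. For the measured compounds named here, the one measured step that bears on this change is a 1.5-fold higher number from compound 1 to compound 2 (0.17 log units; within the scatter), in which one group was exchanged for another at the same aromatic carbon with no movement beyond the scatter. With a third group entering at that same place, the expected step is again no change beyond the scatter, a 1.1-fold lower number from compound 2 to compound 3 (0.04 log units; within the scatter). Compound 3 is therefore estimated at 10 nM in this assay, with a range from 4 nM to 25 nM.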

Compound 3, half-maximal inhibitory concentration: 57 nM
Beside the measured number, compound 3's estimate is 5.7-fold (0.76 log units) below it; the whole stated range lies below it.
By their numbers in this assay, from the lowest: compounds 1 and 2 (each within the scatter of the next); then compound 3.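

At this position, an aromatic carbon para to a large group, the earlier pair suggested free exchange, but acetyl does not fit that reading in this assay: acetyl in place of nitro gives a 5.2-fold higher number from compound 2 to compound 3 (0.71 log units; beyond the scatter) and acetyl in place of methylsulfonyl gives a 7.7-fold higher number from compound 1 to compound 3 (0.89 log units; beyond the scatter) in the same assay. Nitro and acetyl both carry 3 heavy atoms, so an equal heavy-atom count at this carbon does not guarantee an equal number here. Nothing available accounts for the weaker result with acetyl.

Going by these compounds, whether the shift follows the carbonyl or the methyl of the acetyl group stays open. A nitrile, a primary amide, a carboxylic acid or an amine at this carbon would show how far the likeness of compound 1 and compound 2 extends.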